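Replacing 1,3-thiazol-2-yl with 4-fluorophenyl on compound 1

The compounds below may be only part of what the source reports. "The series", "measured", "known", "first", "only" and "open" are said of these compounds alone.

Of the compounds shown here, three have been measured so far in a physicochemical assay for lipophilicity; on this read-out lower numbers stand for lower lipophilicity and higher numbers for higher lipophilicity. Compound 1 `O=S(=O)(Nc1nccs1)c1ccc2c(c1)OCC[C@H]2c1ccc(C(F)(F)F)cc1-c1nccs1` gives 3.3 and compound 3 `O=S(=O)(Nc1nccs1)c1ccc2c(c1)OCC[C@@H]2c1ccc(C(F)(F)F)cc1-c1ccc(F)cn1` gives 3.5, two numbers that lie within the usual scatter of each other. Compound 2 `Cn1nccc1-c1cc(C(F)(F)F)ccc1[C@H]1CCc2cc(S(=O)(=O)Nc3ncccn3)ccc21` gives 2.4, a gap beyond the scatter under the number for compound 1. Compound 1 therefore sits with compound 3 at the upper end of this small set.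

Compound 4 `O=S(=O)(Nc1nccs1)c1ccc2c(c1)OCC[C@H]2c1ccc(C(F)(F)F)cc1-c1ccc(F)cc1` has not been measured yet. It keeps the core of compound 1 and changes one group: 4-fluorophenyl in place of 1,3-thiazol-2-yl on an aromatic carbon. In words, 4-fluorophenyl stands in place of 1,3-thiazol-2-yl on an aromatic carbon, ortho to a large group and meta to a trifluoromethyl group.

Within the data shown here, no measured pair shows this swap on its own, so the expectation is a judgement on the swap itself rather than a measured trend. An upward move beyond the scatter is expected, a number 0.70 log units higher from compound 1 to compound 4 (beyond the scatter). For compound 4 the estimated value is 4, with an expected range from 3.6 to 4.4.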

Compound 4, distribution coefficient: 4.5
Compound 4: the middle estimate sits 0.50 log units below what was measured; measured number outside the range, above it.
By their numbers in this assay, from the lowest: compound 2; then compounds 1 and 3 (each within the scatter of the next); then compound 4.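

Among these compounds, this is the first single-place comparison in the set, and it shows that the ring at this position, on an aromatic carbon, ortho to a large group and meta to a trifluoromethyl group, strongly shapes the reading in this assay: the swap to 4-fluorophenyl gives a number 1.20 log units higher from compound 1 to compound 4 (beyond the scatter) on an otherwise unchanged structure. The two rings differ in several counted ways at once, since 1,3-thiazol-2-yl has five heavy atoms and two hydrogen-bond acceptors, while 4-fluorophenyl has seven heavy atoms and no hydrogen-bond acceptors. No measurement shown explains the size of this step.

Going by these compounds, it remains open how much of the step belongs to the ring and how much to its fluorine, which a plain phenyl group at this position would help to separate. Also open, on these data alone, is how this position would respond to a group of another kind, such as an amine or a carboxylic acid.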